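The source may hold more compounds than are shown below. What is called first, only, known or untested is meant among the compounds shown, and "the series" means these compounds.

In a functional assay on VCaP cells (Homo sapiens) for antiproliferative activity, read by CCK-8 assay, with a stated time of 6 days (on this read-out lower numbers stand for stronger inhibition and higher numbers for weaker inhibition), three compounds that share one core and differ in a single group have been measured. Compound 1 `CCN(c1ccc(C#N)c(Cl)c1)c1cc(C2=CCCCC2)ccc1C`, which carries cyclohex-1-en-1-yl, gives 20000 nM. Compound 2 `CCN(c1ccc(C#N)c(Cl)c1)c1cc(-c2c[nH]nc2C)ccc1C`, with 3-methyl-1H-pyrazol-4-yl, gives 3190 nM. Compound 3 `CCN(c1ccc(C#N)c(Cl)c1)c1cc(-c2cccnc2)ccc1C`, with pyridin-3-yl, gives 1270 nM, the lowest of the three numbers and so the strongest inhibition so far.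

Compound 4 `CCN(c1ccc(C#N)c(Cl)c1)c1cc(-c2ccoc2)ccc1C` has not yet been measured. For the measured compounds named here, it carries furan-3-yl in place of pyridin-3-yl on an aromatic carbon, the only structural difference from compound 3: furan-3-yl in place of pyridin-3-yl on an aromatic carbon.

No furan has been tested in this series, so the estimate must lean on the neighbouring steps. Both a 16-fold lower number from compound 1 to compound 3 (1.20 log units; beyond the scatter) and a 6.3-fold lower number from compound 1 to compound 2 (0.80 log units; beyond the scatter) show that the two aromatic rings give lower numbers than the cyclohexenyl group. The closest guide is a 2.5-fold lower number from compound 2 to compound 3 (0.40 log units; beyond the scatter), a modest step beyond the scatter. It leads from a five-membered aromatic ring to pyridin-3-yl, and the new change runs the opposite way. A modest move towards a higher number in this assay is therefore expected, and the estimated step is a 2.2-fold higher number from compound 3 to compound 4 (0.34 log units; beyond the scatter). The estimate for compound 4 is 2800 nM, with an expected range from 1000 nM to 8000 nM.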

Compound 4, half-maximal inhibitory concentration: 4010 nM
For compound 4 the middle estimate is 1.4-fold (0.16 log units) below the measured one; low and high end bracket the measured number.
By their numbers in this assay, from the lowest: compound 3; then compounds 2 and 4 (each within the scatter of the next); then compound 1.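

Replacing pyridin-3-yl with furan-3-yl on this aromatic carbon gives a 3.2-fold higher number from compound 3 to compound 4 (0.50 log units; beyond the scatter) in this assay, although both groups count no hydrogen-bond donors and one acceptor, so those counts alone do not fix the number at this position. The two five-membered aromatic rings cannot be told apart here, with a 1.3-fold higher number from compound 2 to compound 4 (0.10 log units; within the scatter), which lies within the scatter. Furan-3-yl still clearly improves on cyclohex-1-en-1-yl, with a 5.0-fold lower number from compound 1 to compound 4 (0.70 log units; beyond the scatter), so all three aromatic rings give lower numbers than that group, while pyridin-3-yl alone stands apart from the other two aromatic rings.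

No measurement shown here explains why these groups differ.

The change from pyridin-3-yl to furan-3-yl alters both the ring size and the hetero atom, and the compounds shown do not separate the two; a plain phenyl ring or a thiophene would be needed to do so. Going by these compounds, it also remains open whether a substituent on the pyridine ring, such as an amine or a carboxylic acid, would move the number of compound 3 from 1270 nM in either direction.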